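Swapping a Ring Carbon for Nitrogen on the Amide Aryl

The compounds below may be only part of what the source reports. "The series", "measured", "known", "first", "only" and "open" are said of these compounds alone.

Compound 1, `O=C(COc1ccc2cc(/C=C3/SC(=O)NC3=O)ccc2c1)Nc1ccc(F)cc1`: 1600 nM
Compound 2, `O=C(COc1ccc2cc(/C=C3/SC(=O)NC3=O)ccc2c1)Nc1c(F)cc(F)cc1Br`: 1100 nM
Compound 3, `O=C(COc1ccc2cc(/C=C3/SC(=O)NC3=O)ccc2c1)Nc1ccc(Br)c(Br)c1`: 4900 nM

All three share one core and differ only in the ring on the amide-type nitrogen. In an assay on isolated protein for inhibition of histone deacetylase 4 (Homo sapiens), with a stated time of 1 h (a higher number here means a weaker inhibitor, a lower number a stronger inhibitor), compound 1 stands second highest of the three numbers: nearest to compound 2, with a 1.5-fold lower number from compound 1 to compound 2 (0.16 log units; within the scatter), and furthest from compound 3, with a 3.1-fold higher number from compound 1 to compound 3 (0.49 log units; beyond the scatter). Compound 4, `O=C(COc1ccc2cc(/C=C3/SC(=O)NC3=O)ccc2c1)Nc1cccc(F)n1`, differs from compound 1 in one place: 6-fluoropyridin-2-yl in place of 4-fluorophenyl on an amide-type nitrogen. The measured steps changed only the halogen pattern on an all-carbon ring; none exchanged a ring carbon for nitrogen, so they bear on this change only loosely. The smaller stayed within the scatter and the larger, a 4.5-fold higher number from compound 2 to compound 3 (0.65 log units; beyond the scatter), was modest. In this assay compound 4 is therefore expected to show no step beyond the scatter, no change at the digits printed from compound 1 to compound 4 (within the scatter). Compound 4 is estimated at 1600 nM, with a range from 700 nM to 3600 nM.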

Compound 4, half-maximal inhibitory concentration: 840 nM
Compound 4: the middle estimate sits 1.9-fold (0.28 log units) above what was measured; the range from low to high includes it.
By their numbers in this assay, from the lowest: compounds 4, 2 and 1 (each within the scatter of the next); then compound 3.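

So a ring nitrogen, which brings a hydrogen-bond acceptor to this group, is accepted on the amide-type nitrogen in this assay, with a 1.9-fold lower number from compound 1 to compound 4 (0.28 log units; within the scatter). The 6-fluoropyridin-2-yl group also stays level with 2-bromo-4,6-difluorophenyl, with a 1.3-fold lower number from compound 2 to compound 4 (0.12 log units; within the scatter), and stands clear of 3,4-dibromophenyl, with a 5.8-fold lower number from compound 3 to compound 4 (0.77 log units; beyond the scatter). No measurement at hand says what lies behind these numbers. Whether the ring nitrogen alone accounts for this step stays open, as the fluorine changes its place too. Also open, from the compounds shown here alone, is how an amine or a methoxy group would fare in place of that fluorine.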